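From Formate to Acetate on a Shared Core

This account rests on a few compounds, and the source may have more. Where it says the series, first, only, none or still open, it means among the compounds named here.

Compound 1, `Cc1ccccc1C(=O)OC1(C(=O)Nc2ccc([N+](=O)[O-])cc2)CCCCC1`, gives 352 nM in an ADME assay on WI-38 cells (Homo sapiens) for inhibition, read by MTT assay, with a stated time of 72 h; on this read-out lower numbers stand for stronger inhibition and higher numbers for weaker inhibition.
Compound 2, `O=C(OC1(C(=O)Nc2ccc([N+](=O)[O-])cc2)CCCCC1)c1ccc([N+](=O)[O-])cc1`, gives 761 nM.
Compound 3, `O=COC1(C(=O)Nc2ccc([N+](=O)[O-])cc2)CCCCC1`, gives 46.3 nM.

Compound 3 has the lowest number of the three. The change a 7.6-fold lower number from compound 1 to compound 3 (0.88 log units; beyond the scatter) and the change a 16-fold lower number from compound 2 to compound 3 (1.22 log units; beyond the scatter) both show that replacing a larger aryl ester group by hydrogen lowers the number considerably. Compound 4, `CC(=O)OC1(C(=O)Nc2ccc([N+](=O)[O-])cc2)CCCCC1`, reverses that direction only slightly: methyl in place of hydrogen on a carbonyl carbon. Since a single added carbon is much smaller than the aryl groups removed in those two steps, the expected movement is small, probably a modest rise or nothing beyond the scatter. The estimated step is a 1.7-fold higher number from compound 3 to compound 4 (0.24 log units; within the scatter). For compound 4 the expected value is 80 nM, within a range from 35 nM to 200 nM.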

Compound 4, half-maximal inhibitory concentration: 386 nM
Beside the measured number, compound 4's estimate is 4.8-fold (0.68 log units) below it, and the stated range ends below it.
By their numbers in this assay, from the lowest: compound 3; then compounds 1, 4 and 2 (each within the scatter of the next, the first and the last beyond it).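

In this assay, methyl in place of hydrogen on this carbonyl carbon is enough to lose the low number of the formate: an 8.3-fold higher number from compound 3 to compound 4 (0.92 log units; beyond the scatter). Neither aryl ester can be told apart from the acetoxy compound, with a 2.0-fold lower number from compound 2 to compound 4 (0.29 log units; within the scatter) and a 1.1-fold higher number from compound 1 to compound 4 (0.04 log units; within the scatter). Among these four compounds, then, only the hydrogen of compound 3 stands apart, and the size of the group alone does not set the number. No measurement here explains this. On these data alone, whether a longer chain such as propyl, or an amine, on this carbonyl carbon would behave like methyl or like hydrogen remains open.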